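The source may hold more compounds than are shown below. What is called first, only, known or untested is meant among the compounds shown, and "the series" means these compounds.

Measured so far:
compound 1 `CC[C@@H](O)CNC(=O)C[C@H](CCC1CCCCC1)NC(=O)c1cc(-c2c(OC)cccc2OC)n(CC(C)C)n1`: 0.0517 h
compound 2 `COc1cccc(OC)c1-c1cc(C(=O)N[C@@H](CCC2CCCCC2)CC(=O)NC2CCC2)nn1CC(C)C`: 0.0543 h

In an ADME assay on microsomes from liver (Homo sapiens) for metabolic stability, read by LC-MS, using NADPH, with a stated time of 120 min, tested at 1 uM (a lower number here means that the compound disappears faster, a higher number that the compound lasts longer), compound 2 gives 0.0543 h, the higher of the two numbers; compound 1 gives 0.0517 h. Going by the values given here, the only measured step, a 1.1-fold higher number from compound 1 to compound 2 (0.02 log units; within the scatter), concerns the group on the amide-type nitrogen and stays within the scatter, so the two compounds are not separated.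

Compound 3 `COc1cccc(OC)c1-c1cc(C(=O)N[C@@H](CCC2CCCCC2)CC(=O)NC2CCC2)nn1C1CCCCC1` is not yet measured. It differs from compound 2 by cyclohexyl in place of isobutyl on an aromatic nitrogen. Among the compounds with values here, this change sits on the aromatic nitrogen of the shared core, a place no measured step touches, so none of the measured steps bears on it. Within the data shown here, with no step pointing in either direction, the expected step is a 1.0-fold higher number from compound 2 to compound 3 (0.01 log units; within the scatter), that is, none beyond the scatter. The half-life of compound 3 in this assay is therefore estimated at 0.055 h, with a range from 0.028 h to 0.11 h.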

Compound 3, half-life: 0.105 h
Estimate against measurement, compound 3: 1.9-fold (0.28 log units) below; the range from low to high includes it.
By their numbers in this assay, from the lowest: compounds 1, 2 and 3 (each within the scatter of the next, the first and the last beyond it).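

This position on the aromatic nitrogen of the shared core now has its first reading. In this assay, the isobutyl-to-cyclohexyl change gives a 1.9-fold higher number from compound 2 to compound 3 (0.29 log units; within the scatter), so a six-membered carbon ring in place of isobutyl separates compound 3 from compound 2 by no more than the usual scatter of the half-life. The aromatic nitrogen therefore carries either group without a resolved difference in this assay, although the step is a single pair on one cyclobutyl amide background. No data at hand bear on what lies behind this step.

Still open, going by these compounds, is how a longer chain or a group bearing an amine would read on the aromatic nitrogen in this assay. Also open, on these data alone, is whether cyclohexyl there gives a similar step with 2-hydroxybutyl in place of cyclobutyl on the amide-type nitrogen.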